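This account rests on a few compounds, and the source may have more. Where it says the series, first, only, none or still open, it means among the compounds named here.

Measured so far:
compound 1 `CC(C)N(Cc1cccc(OCCCCCC(=O)O)c1)C(=O)c1ccc(-c2ccncc2)cc1`: > 26000 nM
compound 2 `CC(C)N(Cc1cccc(OCCCCCC(=O)O)c1)C(=O)c1ccc(-c2cccc(Oc3ccccc3)c2)cc1`: > 18700 nM

Both compounds were tested in an ADME assay on HepG2 cells (Homo sapiens) for cytotoxicity, read by CellTiter-Glo and resazurin assay, with a stated time of 72 h; on this read-out lower numbers stand for an effect already at smaller amounts and higher numbers for an effect only at larger amounts of compound. Compound 1 gives > 26000 nM, which is a limit of the assay rather than a number. Compound 2 gives > 18700 nM, likewise a limit. So compound 1 stands only at a limit in this assay, and the one other value shown is a limit as well, so no ordering between the two can be read from these numbers.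

Compound 3 `CCOc1cccc(-c2ccc(C(=O)N(Cc3cccc(OCCCCCC(=O)O)c3)C(C)C)cc2)c1` has not been measured yet. It differs from compound 1 in one place: 3-ethoxyphenyl in place of pyridin-4-yl on an aromatic carbon. For the measured compounds named here, no step between measured compounds is available to guide the expectation, so in this assay no shift beyond the usual scatter is expected from this change.

Compound 3 is therefore estimated to give 30000 nM, in a range from 10000 nM to 100000 nM. That estimate means an expected step that the limit leaves unreadable from compound 1 to compound 3, most likely again reported only as a limit.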

Compound 3, half-maximal effective concentration: > 20800 nM
Compound 3: a limit, no number; the forecaster's own chance of this, stated with the estimate: 75%; the middle value lies beyond the limit too.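

Compound 1, compound 2 and compound 3 each give only a limit in this assay, not a number, and the steps between them cannot be read. The compounds shown leave open whether 3-ethoxyphenyl in place of pyridin-4-yl, or ethyl in place of phenyl, shifts the concentration that affects these cells.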